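Replacing the aryl amide cap with an acetyl group

This account rests on a few compounds, and the source may have more. Where it says the series, first, only, none or still open, it means among the compounds named here.

Of the compounds shown here, three from this series have been tested in a functional assay on NUGC-3 cells (Homo sapiens) for cytotoxicity, read by sulforhodamine B assay, with a stated time of 72 h; on this read-out lower numbers stand for stronger inhibition of growth and higher numbers for weaker inhibition of growth. Compound 2 `O=C(Nc1cc(C(F)(F)F)cc(C(F)(F)F)c1)C1CCc2ccccc2N1C(=O)c1ccc(Cl)cc1` gives 1660 nM in this assay. Compound 1 `CC(=O)N1c2ccccc2CCC1C(=O)Nc1cc(C(F)(F)F)cc(C(F)(F)F)c1` reaches only the assay limit of > 70000 nM in this assay. The step between them, (methyl in place of 4-chlorophenyl on a carbonyl carbon), is measured as an at least 42-fold higher number from compound 2 to compound 1 (1.62 log units; beyond the scatter), and its size is marked by the limit of > 70000 nM in this assay, at which 1 of the 3 values shown sits. Compound 3 `O=C(Nc1ccccc1C(F)(F)F)C1CCc2ccccc2N1C(=O)c1ccc(Cl)cc1` gives 551 nM in this assay, the lowest of the two numbers available; the difference between the cores of compound 3 and compound 2 is not broken down here.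

Compound 4 `CC(=O)N1c2ccccc2CCC1C(=O)Nc1ccccc1C(F)(F)F` has not yet been measured. It differs from compound 3 by methyl in place of 4-chlorophenyl on a carbonyl carbon, the same change that separates compound 2 from compound 1. The author expects the step from compound 3 to compound 4 in this assay to be a 54-fold higher number from compound 3 to compound 4 (1.74 log units; beyond the scatter), resting on the earlier step of an at least 42-fold higher number from compound 2 to compound 1 (1.62 log units; beyond the scatter) from compound 2, whose size can only be bounded because compound 1 sits at the limit of > 70000 nM in this assay, at which 1 of the 3 values shown sits. Compound 4 is therefore estimated at 30000 nM in this assay, with a range from 8000 nM to 100000 nM, and a fair chance that only a limit is reported.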

Compound 4, concentration for 50% growth inhibition: > 80000 nM
Compound 4: a limit, no number; the forecaster's own chance of this, stated with the estimate: 40%; middle value at least 2.6-fold (0.42 log units) from the limit.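

In this assay, putting methyl in place of 4-chlorophenyl on the carbonyl carbon gives an at least 140-fold higher number from compound 3 to compound 4 (2.16 log units; beyond the scatter), so the large loss of growth inhibition seen with this change on one core appears again on the second. Compound 4 sits at a limit of the assay, > 80000 nM, which is not a number. The direction of the change therefore carries across the two cores shown, but the comparison says nothing firm about whether its size is the same on both: the same change on two cores in this assay, an at least 42-fold higher number (1.62 log units; beyond the scatter) from compound 2 to compound 1 and an at least 140-fold higher number (2.16 log units; beyond the scatter) from compound 3 to compound 4; the limit leaves it open whether they differ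

With only the 4-chlorophenyl and methyl caps on show, the compounds leave open which part of the larger cap matters, and whether a plain phenyl ring, a cyclohexyl ring or a longer chain such as butanoyl would retain any of the growth inhibition. From the compounds shown here alone, it also remains open how a cap carrying an amine or a carboxylic acid would behave on either core.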